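A few compounds are considered here, and "the series" means these few. Any claim that something is new, unique, unknown or untested is made for them only; others in the source may bear on it.

Measured in a functional assay on CCRF-CEM cells (Homo sapiens) for cytotoxicity; a lower number here means a stronger inhibitor, a higher number a weaker inhibitor:
Compound 1 `Nc1ccn([C@@H]2CC(F)(F)[C@H](CO)O2)c(=O)n1`: > 100000 nM
Compound 2 `Nc1ccn([C@H]2CC(F)(F)[C@H](CO)O2)c(=O)n1`: > 100000 nM
Compound 3 `Nc1nc(=O)n([C@@H]2CC(F)(F)[C@H](CO)O2)cc1F`: > 100000 nM

None of these entries is a number. Each is a limit of the assay, as the limit of > 100000 nM in this assay, at which 3 of the 3 values shown sit, records. From the compounds shown here alone, compound 3 stands only at its limit of > 100000 nM, so its true position in this assay is unknown.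

Compound 4 `Nc1nc(=O)n([C@H]2CC(F)(F)[C@H](CO)O2)cc1F` has not yet been measured. It relates to compound 3 as follows: the two compounds have the same atoms and bonds and differ only in configuration as drawn: 1 of 2 stereo elements differ; a stereocentre at a saturated ring carbon is drawn S in compound 3 and R in compound 4. A stereocentre at a saturated ring carbon is drawn S in compound 3 and R in compound 4, and nothing else changes.

For the measured compounds named here, two measured steps bear on this. The only one of the same kind is a step that the two limits leave unreadable from compound 1 to compound 2. The other, fluoro in place of hydrogen on an aromatic carbon, is a step that the two limits leave unreadable from compound 1 to compound 3. Neither has a readable size, so neither supplies a size or direction to carry over. No step beyond the scatter is therefore expected in this assay, and compound 4 will most likely be reported as a limit as well. The expected step is a step that the limit leaves unreadable from compound 3 to compound 4. The estimate for compound 4 is 120000 nM, with the value expected to fall between 40000 nM and 300000 nM.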

Compound 4, half-maximal inhibitory concentration: > 100000 nM
Compound 4: only a limit was reported; the forecaster's own chance of this, stated with the estimate: 85%; the middle value is on the limit's open side.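

In this assay compound 4 gives > 100000 nM, which is a limit of the assay and not a number, so no new step can be read between it and compound 3 or compound 2. The compounds shown leave open whether the change in configuration, or fluoro in place of hydrogen, alters cytotoxicity at all.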